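Propargyl in place of methyl on the aniline nitrogen

The source may hold more compounds than are shown below. What is called first, only, known or untested is meant among the compounds shown, and "the series" means these compounds.

Measured compounds:
compound 1 `C#CCN(Cc1ccc2nc(C)nc(O)c2c1)c1ccc(C(=O)N[C@@H](CCC(=O)O)C(=O)N[C@@H](CCC(=O)O)C(=O)O)cc1` gives 160 nM
compound 2 `Cc1nc(O)c2cc(CN(C)c3ccc(C(=O)N[C@@H](CCC(=O)O)C(=O)N(C)[C@@H](CCC(=O)O)C(=O)O)c(F)c3)ccc2n1` gives 2400 nM
compound 3 `Cc1nc(O)c2cc(CN(C)c3ccc(C(=O)N[C@@H](CCC(=O)O)C(=O)N(C)[C@@H](CCC(=O)O)C(=O)O)c(F)c3)c(C)cc2n1` gives 730 nM

All three were run in a functional assay (L1210 cells) for inhibition, with Mus musculus as the target; a higher number here means a weaker inhibitor, a lower number a stronger inhibitor. Compound 2 stands at the highest number of the three: the nearest is compound 3, reached by a 3.3-fold lower number from compound 2 to compound 3 (0.52 log units; beyond the scatter), and the furthest is compound 1, whose value sits far lower. Compound 1 and compound 2 differ in more than one place, so their two values show only that the propargyl-bearing, fluorine-free, unmethylated-amide compound lies well below the other.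

Compound 4 `C#CCN(Cc1ccc2nc(C)nc(O)c2c1)c1ccc(C(=O)N[C@@H](CCC(=O)O)C(=O)N(C)[C@@H](CCC(=O)O)C(=O)O)c(F)c1` is the next step from compound 2: ethynyl in place of hydrogen on a saturated chain carbon bound to a nitrogen on an aromatic ring. For the measured compounds named here, no measured step covers this exact change. Going by the values given here, the only one-place step, from compound 2 to compound 3, concerns a methyl on an aromatic carbon and was modest; it gives no guidance on the chain nitrogen substituent. The gap between compound 1 and compound 2 is the sole hint that the ethynyl extension may be favourable, but it is confounded by the fluorine and the amide methyl.

A step to a lower number is therefore expected for compound 4, a 3.0-fold lower number from compound 2 to compound 4 (0.48 log units; beyond the scatter), with wide uncertainty. Compound 4 is estimated at 800 nM, between 250 nM and 2500 nM.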

Compound 4, half-maximal inhibitory concentration: 230 nM
For compound 4 the middle estimate is 3.5-fold (0.54 log units) above the measured one; the whole stated range lies above it.
By their numbers in this assay, from the lowest: compounds 1 and 4 (each within the scatter of the next); then compound 3; then compound 2.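

In this assay, methyl to propargyl gives a 10-fold lower number from compound 2 to compound 4 (1.02 log units; beyond the scatter), with ethynyl in place of hydrogen on a saturated chain carbon bound to a nitrogen on an aromatic ring. The fluorine and the amide methyl are the same in both compounds, so this step reads the position on its own, whereas the gap between compound 1 and compound 2 could not be assigned to any single place. For the compounds shown here, the only earlier one-place reading, a 3.3-fold lower number from compound 2 to compound 3 (0.52 log units; beyond the scatter), concerned a methyl on an aromatic carbon and said nothing about this position; no measurement in hand bears on why the propargyl change moves the number.

Open, going by these compounds, is whether the step depends on the triple bond or on chain length alone, which a propyl or allyl group on the same nitrogen would help to separate. Also open, on these data alone, is whether the propargyl change and the methyl on the aromatic carbon in compound 3 would add up when carried together in one compound.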